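The compounds below may be only part of what the source reports. "The series", "measured", "known", "first", "only" and "open" are said of these compounds alone.

Measured so far, in a functional assay on MV4-11 cells (Homo sapiens) for inhibition, with a stated time of 120 h, tested at 10 uM; a lower number here means less inhibition, a higher number more inhibition at the concentration tested (going by the name of the read-out):
- compound 1, `Cc1n[nH]c2ccc(-c3nc4cnc(N5CCN(C)CC5)cn4c3Nc3cccc(F)c3)cc12`, gives 18.5%
- compound 2, `Cc1n[nH]c2ccc(-c3nc4cnc(N5CCN(C)CC5)cn4c3Nc3ccc(F)cc3)cc12`, gives 0%
- compound 3, `Cc1n[nH]c2ccc(-c3nc4cnc(N5CCN(C)CC5)cn4c3Nc3ccc(Cl)cc3)cc12`, gives 83.7%

Three compounds share one core and differ only in the ring carried on the nitrogen. Among them compound 3 stands highest in this assay: its nearest neighbour is compound 1, and the gap is a number 65.2 percentage points higher from compound 1 to compound 3 (beyond the scatter); the furthest is compound 2, with a number 83.7 percentage points higher from compound 2 to compound 3 (beyond the scatter).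

Compound 4, `Cc1n[nH]c2ccc(-c3nc4cnc(N5CCN(C)CC5)cn4c3Nc3ccc(I)cc3)cc12`, differs from compound 3 in one place: iodo in place of chloro on an aromatic carbon.

Among the compounds with values here, the step that bears most directly on this is the one from compound 2 to compound 3, where one halogen replaced another on the same aromatic carbon and the read-out moved by a number 83.7 percentage points higher from compound 2 to compound 3 (beyond the scatter), a large rise. The step of a number 65.2 percentage points higher from compound 1 to compound 3 (beyond the scatter) also ends at compound 3 and points the same way. Only two halogens have been tried at this carbon, so the direction of a further swap is not settled by the data; the single large rise seen so far, from fluoro to chloro, leaves compound 3 already near the top of the scale, which limits how much further the number can climb.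

Compound 4 is therefore expected to stay high, with a step of a number 1.3 percentage points higher from compound 3 to compound 4 (within the scatter) estimated, and the estimate for compound 4 is 85%, with a range from 55% to 100%.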

Compound 4, a percentage reported as inhibition, at one concentration (the size of the read-out at that concentration, not a potency): 0%
Compound 4: middle estimate off by 85 percentage points, on the high side; the whole stated range lies above it.
By their numbers in this assay, from the lowest: compounds 2 and 4 (each within the scatter of the next); then compound 1; then compound 3.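

In this assay, the rise from fluoro to chloro on this aromatic carbon does not carry on to iodo: a number 83.7 percentage points lower from compound 3 to compound 4 (beyond the scatter) wipes out the whole gain, while no change at the digits printed from compound 2 to compound 4 (within the scatter) leaves the fluoro and iodo compounds level. Among the three halogens tried at this carbon, then, only chloro gives a high number, so the read-out does not climb steadily from one halogen to the next, and swapping a single atom here can take it from near the top of the scale to nothing. Within the data shown here, the iodo compound also falls short of the one compound carrying its fluoro elsewhere on the ring, with a number 18.5 percentage points lower from compound 1 to compound 4 (beyond the scatter) as the modest step, and no measurement at hand explains why chloro alone stands out.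

Bromo on the same carbon would show whether the high number belongs to chloro alone or also extends to a neighbouring halogen, and a methyl or methoxy group there would show whether a non-halogen can give it too. A 3-chlorophenyl ring would separate the effect of the halogen from that of its place on the ring, which compounds with only a single fluoro at that other place cannot do.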